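Indole in Place of Benzodioxin: Expected Cytotoxicity

A few compounds are considered here, and "the series" means these few. Any claim that something is new, unique, unknown or untested is made for them only; others in the source may bear on it.

Compound 1 `CCOC(=O)CCCCCOc1cccc(CN(C(=O)c2ccc(-c3cccc(OC(C)C)c3)cc2)C(C)C)c1` and compound 2 `CCOC(=O)CCCCCOc1cccc(CN(C(=O)c2ccc(-c3ccc4c(c3)OCCO4)cc2)C(C)C)c1` share one core and differ only in the aryl group at the far end of the biaryl. In an ADME assay on HEK293 cells (Homo sapiens) for cytotoxicity, read by CellTiter-Glo and resazurin assay, with a stated time of 72 h (a lower number here means that less compound is needed, a higher number that more compound is needed for the effect), compound 1 gives > 26000 nM, which is a limit of the assay and not a number. Compound 2 gives > 24400 nM in this assay, again a limit. With both values at limits, the step that the two limits leave unreadable from compound 1 to compound 2 cannot be sized; the two limits are the limit of > 26000 nM in this assay, at which 1 of the 2 values shown sits, and (the limit of > 24400 nM in this assay, at which 1 of the 2 values shown sits). Going by the values given here, compound 2 thus stands at a limit, as does the one other value known.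

Compound 3 `CCOC(=O)CCCCCOc1cccc(CN(C(=O)c2ccc(-c3ccc4cc[nH]c4c3)cc2)C(C)C)c1` carries the change (1H-indol-6-yl in place of 2,3-dihydro-1,4-benzodioxin-6-yl on an aromatic carbon). Among the compounds with values here, the only measured step at this position, from compound 1 to compound 2, is unreadable, so no step beyond the scatter is expected. The estimated step that the limit leaves unreadable from compound 2 to compound 3 therefore means no change in this assay. Compound 3 is expected to give 30000 nM, within 15000 nM to 60000 nM, most likely reported only as a limit.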

Compound 3, half-maximal effective concentration: > 26000 nM
Compound 3 was reported as a limit; the forecaster's own chance of this, stated with the estimate: 80%; the middle value does not contradict the limit.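

With compound 3 also reported only as a limit in this assay, the steps linking compound 1, compound 2 and compound 3 cannot be read. The compounds shown leave open whether any of these aryl groups changes cytotoxicity, and at what concentration such an effect would appear.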